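The source may report more compounds than this note shows. Statements on the series, on what has been measured and on what is new or still open speak of the compounds shown alone.

Measured so far:
- compound 1 `CCCc1cc(N2CCCC2)c2cc(NC(=O)/C=C/c3ccc(C(F)(F)F)cc3)ccc2n1`: 2800 nM
- compound 2 `CC(C)c1cc(N)c2cc(NC(=O)/C=C/c3ccc(C(F)(F)F)cc3)ccc2n1`: 160 nM

In a functional assay on HEK293 cells for activation of melanin-concentrating hormone receptor 1 (Homo sapiens), read by inositol phosphate accumulation (on this read-out higher numbers stand for an effect only at larger amounts of compound and lower numbers for an effect already at smaller amounts), compound 2 holds the lower of the two numbers, and the nearest value, that of compound 1, lies beyond the usual scatter. Compound 3 `Nc1cc(C2CCCCC2)nc2ccc(NC(=O)/C=C/c3ccc(C(F)(F)F)cc3)cc12` has not been measured; it differs from compound 2 by cyclohexyl in place of isopropyl on an aromatic carbon. For the measured compounds named here, no comparable step between measured compounds is available, so the expected step is small, with no clear direction beyond the scatter. Compound 3 is expected to give 200 nM, within 60 nM to 700 nM, an expected step of a 1.3-fold higher number from compound 2 to compound 3 (0.10 log units; within the scatter).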

Compound 3, half-maximal effective concentration: 96 nM
For compound 3 the middle estimate is 2.1-fold (0.32 log units) above the measured one; the range from low to high includes it.
By their numbers in this assay, from the lowest: compounds 3 and 2 (each within the scatter of the next); then compound 1.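

For the compounds shown here, on the aromatic carbon next to the ring nitrogen, cyclohexyl in place of isopropyl gives a 1.7-fold lower number from compound 2 to compound 3 (0.22 log units; within the scatter) in this assay and offers the first single-place comparison. At this position, the six-membered carbon ring and the smaller isopropyl group therefore give values within the scatter of each other. Nothing shown explains this result.

Open, on these data alone, is whether phenyl, a longer chain such as n-hexyl, or a piperidine ring would stay within the scatter here. As far as these compounds go, the separate contribution of the amino group also remains open, as compound 1 differs from compound 2 in more than one place.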